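The source may hold more compounds than are shown below. What is called first, only, known or untested is meant among the compounds shown, and "the series" means these compounds.

Compound 1, `O=C1c2cc(Cl)c(Cl)cc2C(=O)N1c1ncccn1`: 32%
Compound 2, `O=C1c2c(Cl)c(Cl)c(Cl)c(Cl)c2C(=O)N1Cc1ccccn1`: 23%
Compound 3, `O=C1c2c(Br)c(Br)c(Br)c(Br)c2C(=O)N1Cc1ccccn1`: 35%

Of the compounds shown here, three have been measured in a functional assay on the whole organism with Rattus norvegicus as the target, read by spectrophotometry, with stated times of 14 days and 3 days, at a dose of 10 mg/kg by the oral route; on this read-out lower numbers stand for less inhibition and higher numbers for more inhibition at the one dose given (going by the name of the read-out). Compound 2 has the lowest of the three numbers, but its neighbour compound 1 sits within the usual scatter of it, so the two cannot be put in order; only compound 3 lies beyond the scatter of compound 2, with the higher number. Within the data shown here, compound 1 and compound 3 differ from compound 2 in more than one place, so no single step between measured compounds can be read off.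

The compound still to be measured is compound 4, `O=C1c2c(Cl)c(Cl)c(Cl)c(Cl)c2C(=O)N1c1ccncc1`. Against compound 2 the change is pyridin-4-yl in place of (pyridin-2-yl)methyl on an amide-type nitrogen in a ring. Among the measured compounds shown here, nothing among the measured compounds isolates this change, so the expectation rests on the spread of the three numbers alone, which covers a fairly narrow band. The step from compound 2 to compound 4 is expected to be small, a number 7 percentage points higher from compound 2 to compound 4 (within the scatter), most likely not beyond the scatter and if anything upward, since the other two numbers in this assay lie above compound 2. Compound 4 is therefore estimated at 30% in this assay, within a range from 15% to 48%.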

Compound 4, a percentage reported as inhibition, in the whole organism at one dose (the size of the read-out at that dose, not a potency): 3%
For compound 4 the middle estimate is 27 percentage points above the measured one, and the stated range ends above it.
By their numbers in this assay, from the lowest: compound 4; then compounds 2, 1 and 3 (each within the scatter of the next, the first and the last beyond it).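

In this assay, among these compounds, putting pyridin-4-yl in place of (pyridin-2-yl)methyl on the amide-type nitrogen in a ring gives a number 20 percentage points lower from compound 2 to compound 4 (beyond the scatter), the only step in this set that changes a single place. The earlier compounds shown here could not show that this nitrogen's substituent alone moves the read-out at the one dose given, yet here it does, although the group that leaves and the group that enters each hold one six-membered aromatic ring with 1 hetero atom and carry no net charge. Nothing given here accounts for this difference.

On these data alone, the step combines two changes, the loss of the methyl link and a different attachment on the pyridine ring, so it remains open which of them goes with the lower number; pyridin-2-yl or (pyridin-4-yl)methyl on this nitrogen would separate them. Steps linking compound 1 or compound 3 to the others cannot be read, and it also remains open how a longer chain ending in an amine or a carboxylic acid would behave in this assay at this nitrogen.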